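Swapping a Ring Carbon for Nitrogen in a Weak Inhibitor

The source may report more compounds than this note shows. Statements on the series, on what has been measured and on what is new or still open speak of the compounds shown alone.

compound 1 `Nc1ccn(C[C@H](O)[C@H]2OC(=O)C(OCc3ccccc3)=C2OCc2ccccc2)c(=O)n1`: in a functional assay on HepG2 cells (Homo sapiens) for inhibition, read by MTT assay, with a stated time of 72 h (a lower number here means a stronger inhibitor, a higher number a weaker inhibitor), compound 1 gives 44300 nM.
compound 2 `NC1(CCn2ccc(=O)[nH]c2=O)OC(=O)C(OCc2ccccc2)=C1OCc1ccccc1`: in this assay compound 2 gives > 100000 nM, which is a limit of the assay and not a number.

Within the data shown here, compound 1 is the only compound here with a numeric value, and that value marks weak inhibition; the other entry sits at the limit of > 100000 nM in this assay, at which 1 of the 2 values shown sits. Compound 3 `Nc1ncn(C[C@H](O)[C@H]2OC(=O)C(OCc3ccccc3)=C2OCc2ccccc2)c(=O)n1` differs from compound 1 by a group of 8 heavy atoms (3 carbon, 4 nitrogen, 1 oxygen; one six-membered aromatic ring with 3 hetero atoms) in place of a group of 8 heavy atoms (4 carbon, 3 nitrogen, 1 oxygen; one six-membered aromatic ring with 2 hetero atoms), on a saturated chain carbon, two bonds along the chain from an oxygen on a saturated carbon and a saturated ring carbon. No comparable step has been measured among these compounds, so any expectation rests on compound 1 alone. Compound 3 is expected to stay close to compound 1, a step of a 1.1-fold lower number from compound 1 to compound 3 (0.04 log units; within the scatter) that is not beyond the scatter. The estimate for compound 3 is 40000 nM, ranging from 10000 nM to 150000 nM.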

Compound 3, half-maximal inhibitory concentration: > 100000 nM
Compound 3: only a limit was reported; the forecaster's own chance of this, stated with the estimate: 30%; at least 2.5-fold (0.39 log units) between middle value and limit.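

In this assay, changing one ring carbon to nitrogen, so that a six-membered aromatic ring with 3 hetero atoms replaces one with 2, gives an at least 2.2-fold higher number from compound 1 to compound 3 (0.35 log units; beyond the scatter) and so is not a neutral swap. Even for an inhibitor as weak as compound 1, this ring does not accept the change freely. Compound 3 gives a limit of the assay and not a number, so the true size of the loss stays unknown: the limit of > 100000 nM in this assay, at which 2 of the 3 values shown sit.

On these data alone, whether a methyl group or a fluorine atom on that same ring carbon would do better or worse than the nitrogen remains open. So does whether any change to this ring can give a stronger inhibitor than compound 1.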